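Swapping bromo for iodo in a small cytotoxicity series

A few compounds are considered here, and "the series" means these few. Any claim that something is new, unique, unknown or untested is made for them only; others in the source may bear on it.

Two compounds share this story so far, both tested in a functional assay on GC3/C1 cells (Homo sapiens) for cytotoxicity, read by MTT assay, with a stated time of 6 days (on this read-out lower numbers stand for stronger inhibition and higher numbers for weaker inhibition), on cultured human cells. Among the compounds with values here, in that test compound 1 `CC(=O)N[C@@H](CSC(=O)Nc1ccc(Br)cc1)C(=O)O` gives 63500 nM as its result, and this is the only true number available. Compound 2 `COc1ccccc1CNC(=O)SC[C@H](NC(C)=O)C(=O)O` gives > 200000 nM in this assay and that entry is a limit of the assay, not a number.

The next compound keeps almost everything from compound 1. Compound 3 `CC(=O)N[C@@H](CSC(=O)Nc1ccc(I)cc1)C(=O)O` has iodo in place of bromo on an aromatic carbon and that carbon sits on a six-membered aromatic ring of carbon only, para to a large group. The rest of the core stays the same.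

Within the data shown here, no measured pair in this set shows what such a swap does, so compound 1 at 63500 nM is the only anchor for a forecast. The expected step of a 1.3-fold lower number from compound 1 to compound 3 (0.10 log units; within the scatter) is no larger than the usual scatter of repeated measurements, with no firm direction. Compound 3 is estimated at 50000 nM with an expected range of 20000 nM to 130000 nM in this assay when its result arrives.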

Compound 3, half-maximal inhibitory concentration: > 200000 nM
Compound 3 gave a limit, no number; the forecaster's own chance of this, stated with the estimate: 12%; middle value at least 4.0-fold (0.60 log units) from the limit.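

On the aromatic ring, para to a large group, bromo and iodo are not interchangeable: in this assay, this single swap gives an at least 3.1-fold higher number from compound 1 to compound 3 (0.49 log units; beyond the scatter). Within the data shown here, this is the first measured pair, and it shows that this one position can shift the result on its own, with the rest of the core unchanged and with no ring, hydrogen-bond donor, hydrogen-bond acceptor or net charge entering or leaving. On these data alone, the entry for compound 3 is a limit, not a number, so the true size of the step stays unknown, and the same limit recurs across this small series: the limit of > 200000 nM in this assay, at which 2 of the 3 values shown sit.

The compounds shown leave open what a chloro group, a fluoro group, a plain hydrogen or an amine at this place would do, and so whether the change seen here belongs to iodo alone or is part of a wider trend among such groups. Among these compounds, with compound 1 as the only compound that has a true number, they also cannot show whether any change at this place would give a lower number.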